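The source may report more compounds than this note shows. Statements on the series, on what has been measured and on what is new or still open speak of the compounds shown alone.

Measured so far in a functional assay on L1210 cells (Mus musculus), with a stated time of 48 h; a higher number here means a weaker inhibitor, a lower number a stronger inhibitor:

Compound 1, `O=C1Nc2cc(Cl)c(F)cc2/C1=N/NC(=S)Nc1ccc(Cl)cc1`: 69000 nM.
Compound 2, `Cc1ccc(NC(=S)N/N=C2\C(=O)Nc3cc(Cl)c(F)cc32)cc1`: 166000 nM.
Compound 3, `O=C1/C(=N\NC(=S)Nc2ccc(Cl)cc2)c2cc(Br)ccc2N1Cc1ccc(F)cc1`: 196000 nM.

Compounds 1 and 2 share a core and differ in one place: methyl in place of chloro on an aromatic carbon. On this assay the step is a 2.4-fold higher number from compound 1 to compound 2 (0.38 log units; beyond the scatter), a modest move toward weaker inhibition that lies beyond the usual scatter. Compound 3 carries a different core; how it differs from compound 1 is not broken down here. Its value sits close to that of compound 2, within the scatter, so no order between the two is read. Against compound 1 the gap is larger and beyond the scatter, compound 1 giving the lower number of the two.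

Compound 4, `Cc1ccc(NC(=S)N/N=C2\C(=O)N(Cc3ccc(F)cc3)c3ccc(Br)cc32)cc1`, is not yet measured. It differs from compound 3 in exactly one place: methyl in place of chloro on an aromatic carbon. The place is the same word for word as in the pair of compound 1 and compound 2, so this is the same change made on the second core.

Within the data shown here, with only one measured instance of this change, the expectation rests on compound 1 and compound 2, whose step is a 2.4-fold higher number from compound 1 to compound 2 (0.38 log units; beyond the scatter). For compound 4 a step of a 2.1-fold higher number from compound 3 to compound 4 (0.33 log units; beyond the scatter) is expected, on the assumption that the second core carries the change in a similar way. Compound 4 is estimated at 420000 nM, between 200000 nM and 900000 nM; since compound 3 already stands high, a limit rather than a number is a real possibility.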

Compound 4, half-maximal inhibitory concentration: 190000 nM
For compound 4 the middle estimate is 2.2-fold (0.34 log units) above the measured one; measured number below the stated range.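

In this assay, the swap from 4-chlorophenyl to 4-methylphenyl on the second core gives a 1.0-fold lower number from compound 3 to compound 4 (0.01 log units; within the scatter), so no effect of the change can be read on this core. Set beside the step on the first core, this result cannot be told apart from it: the same change on two cores in this assay, a 2.4-fold higher number (0.38 log units; beyond the scatter) from compound 1 to compound 2 and a 1.0-fold lower number (0.01 log units; within the scatter) from compound 3 to compound 4, 2.5-fold (0.39 log units) apart, within the scatter of two such steps. The two pairs therefore give no ground for saying that the cores take the change differently, but they also do not show that it carries over with a fixed size, since the step beyond the scatter on one core has no counterpart beyond the scatter on the other, and two pairs are a thin base for any rule in this series.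

The compounds shown hold only chloro and methyl at this place, so it remains open whether a group of another kind there, such as methoxy, an amine or a carboxylic acid, would move the number on either core. On these data alone, it also remains open whether such a group would give steps of similar size on both cores, which would be a firmer test of transfer than the present pairs allow.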